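This account rests on a few compounds, and the source may have more. Where it says the series, first, only, none or still open, it means among the compounds named here.

Compound 1 `NCCCCN(C[C@H]1Cc2ncccc2CN1)[C@H]1CCCc2cccnc21` is the better of the two measured compounds in an ADME assay for permeability, using PAMPA, with a stated time of 4 h, at pH 5.5 (a higher number here means that the compound crosses the layer faster, a lower number that the compound crosses the layer more slowly), where compound 1 gives 17 nm/s. Its mirror-configured partner, compound 2 `NCCCCN(C[C@@H]1Cc2ncccc2CN1)[C@H]1CCCc2cccnc21`, gives 2 nm/s. That gap, an 8.5-fold lower number from compound 1 to compound 2 (0.93 log units; beyond the scatter), arises from the fact that compounds 1 and 2 differ only in the configuration as drawn, and it shows how far this read-out can move with no atom added or removed.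

The next compound, compound 3 `NC(=O)NCCCCN(C[C@H]1Cc2ncccc2CN1)[C@H]1CCCc2cccnc21`, keeps the core of compound 1 and changes the end of the chain, turning amino into ureido: carbamoyl in place of hydrogen on an amine nitrogen. In words, a carbamoyl group takes the place of a hydrogen on an amine nitrogen. Among the compounds with values here, no measured step touches this nitrogen, so the data offer only a guide to size, set by the step of an 8.5-fold lower number from compound 1 to compound 2 (0.93 log units; beyond the scatter), and no direct guide to direction. A modest rise is tentatively expected, and the wide range leaves room for a fall. The expected change is a 2.4-fold higher number from compound 1 to compound 3 (0.37 log units; beyond the scatter). For compound 3 the estimated value is 40 nm/s, with an expected range from 8 nm/s to 150 nm/s.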

Compound 3, apparent permeability: 7 nm/s
The estimate for compound 3 lay 5.7-fold (0.76 log units) above the measured number; the whole stated range lies above it.
By their numbers in this assay, from the lowest: compound 2; then compound 3; then compound 1.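

At the end of the chain, this position does respond to a change of atoms and not only to a change of drawn configuration: carbamoyl in place of hydrogen on an amine nitrogen gives, in this assay, a 2.4-fold lower number from compound 1 to compound 3 (0.39 log units; beyond the scatter) and the number falls with the core of compound 1 left untouched. The earlier pair, at an 8.5-fold lower number from compound 1 to compound 2 (0.93 log units; beyond the scatter) as its step, gave a size for what this read-out can do but said nothing about this nitrogen, and the new step now adds a direction for this one change, with a size that is the smaller of the two. Nothing known about these compounds explains the fall, since the one supporting fact concerns the configuration pair and not the ureido end of the chain.

The compounds shown leave open whether the same carbamoyl change would lower the number on the configuration of compound 2. They also leave open what other groups on this amine nitrogen would do, such as an acetyl or a methyl group, or whether the ureido group would behave the same way on a longer chain.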